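Urea aryl substituent series: chloro replaces methoxy

This account rests on a few compounds, and the source may have more. Where it says the series, first, only, none or still open, it means among the compounds named here.

Measured in a functional assay on A549 cells (Homo sapiens) for antiproliferative activity, read by MTT assay; a higher number here means a weaker inhibitor, a lower number a stronger inhibitor:
compound 1 `Cc1ccccc1NC(=O)Nc1cccc(CNc2ncnc3ccccc23)c1`, 40200 nM
compound 2 `Cc1ccc(NC(=O)Nc2cccc(CNc3ncnc4ccccc34)c2)cc1`, 24900 nM
compound 3 `COc1ccccc1NC(=O)Nc1cccc(CNc2ncnc3ccccc23)c1`, 30800 nM

Compound 3 gives the second highest of the three numbers; its nearest neighbour is compound 2 (a 1.2-fold higher number from compound 2 to compound 3 (0.09 log units; within the scatter)) and its furthest compound 1 (a 1.3-fold lower number from compound 1 to compound 3 (0.12 log units; within the scatter)), both steps within the scatter. Compound 4 `O=C(Nc1cccc(CNc2ncnc3ccccc23)c1)Nc1ccccc1Cl` differs from compound 3 by chloro in place of methoxy on an aromatic carbon. Within the data shown here, the steps that bear on this are a 1.3-fold lower number from compound 1 to compound 3 (0.12 log units; within the scatter), also a change on an aromatic carbon of the same phenyl, and a 1.6-fold lower number from compound 1 to compound 2 (0.21 log units; within the scatter); neither leaves the scatter. Nothing measured here separates one small group on that ring from another. The expected step is therefore a 1.0-fold lower number from compound 3 to compound 4 (0.01 log units; within the scatter), with no direction beyond the scatter. Compound 4 is estimated at 30000 nM, range 12000 nM to 75000 nM.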

Compound 4, half-maximal inhibitory concentration: 18000 nM
Beside the measured number, compound 4's estimate is 1.7-fold (0.22 log units) above it, within the range that was stated.
By their numbers in this assay, from the lowest: compounds 4, 2, 3 and 1 (each within the scatter of the next, the first and the last beyond it).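

In this assay, among these compounds, chloro gives the only step in this set that passes the scatter: a 2.2-fold lower number from compound 1 to compound 4 (0.35 log units; beyond the scatter). That step separates 2-chlorophenyl from 2-methylphenyl alone, since a 1.7-fold lower number from compound 3 to compound 4 (0.23 log units; within the scatter) and a 1.4-fold lower number from compound 2 to compound 4 (0.14 log units; within the scatter) both stay within the scatter, so 2-methoxyphenyl and 4-methylphenyl are not separated from it. No evidence is available to account for the step.

Open, on these data alone, is whether 4-chlorophenyl would read like 2-chlorophenyl. Also open, as far as these compounds go, is whether an amine or a carboxylic acid on this ring would give a step beyond the scatter from compound 4.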